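Piperazinyl in place of propylamino on the coumarin series

The source may hold more compounds than are shown below. What is called first, only, known or untested is meant among the compounds shown, and "the series" means these compounds.

Three compounds of the shared core carry a hydroxypropoxy chain ending in an amine. Compound 1 `CCN(CC)CC(O)COc1ccc2oc(=O)cc(C)c2c1` gives 0.0052 ug/mL in a functional assay on ileum for antagonist activity at histamine H1 receptor (Cavia porcellus), tested at 0.1 mg/mL; a lower number here means that less compound is needed, a higher number that more compound is needed for the effect. Compound 2 `Cc1cc(=O)oc2ccc(OCC(O)CN3CCN(c4ccccc4)CC3)cc12` gives 0.0052 ug/mL in this assay. Compound 3 `CCCNCC(O)COc1ccc2c(-c3ccccc3)cc(=O)oc2c1` gives 0.0056 ug/mL in this assay, and both other numbers lie within the scatter of it, so no ordering among the three is supported. Compound 4 `O=c1cc(-c2ccccc2)c2ccc(OCC(O)CN3CCNCC3)cc2o1` is not yet measured; it differs from compound 3 by piperazin-1-yl in place of propylamino on a saturated chain carbon, two bonds along the chain from an oxygen on a saturated carbon. Among the measured compounds shown here, no step between measured compounds bears on this change. Compound 2, which also carries a piperazine ring on that chain carbon, gives 0.0052 ug/mL, so no step beyond the scatter is expected from compound 3 to compound 4 in this assay; the expected step is a 1.1-fold higher number from compound 3 to compound 4 (0.03 log units; within the scatter). Compound 4 is expected to give 0.006 ug/mL, within 0.002 ug/mL to 0.02 ug/mL.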

Compound 4, half-maximal effective concentration: 0.0058 ug/mL
Compound 4: the middle estimate sits 1.0-fold (0.01 log units) above what was measured, and the stated range covers the measured number.
By their numbers in this assay, from the lowest: compounds 1, 2, 3 and 4 (each within the scatter of the next).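

Piperazin-1-yl in place of propylamino on a saturated chain carbon, two bonds along the chain from an oxygen on a saturated carbon, gives a 1.0-fold higher number from compound 3 to compound 4 (0.02 log units; within the scatter) in this assay as the first direct reading of this change. This position therefore accepts a six-membered non-aromatic ring in place of the open propylamino group without a step beyond the scatter. Nothing available bears on why this is so.

Going by these compounds, whether morpholin-4-yl or a longer chain on the amine nitrogen would also stay within the scatter remains open. The same applies to a carboxylic acid at this position.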